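The source may hold more compounds than are shown below. What is called first, only, known or untested is meant among the compounds shown, and "the series" means these compounds.

Measured so far:
compound 1 `O=C(CN1CCN(c2ccccn2)CC1)Nc1cccnc1` — in an assay on cells for agonist activity at D(4) dopamine receptor (Homo sapiens), read by luminescence and beta-arrestin recruitment, with a stated time of 90 min (a lower number here means that less compound is needed, a higher number that more compound is needed for the effect), compound 1 gives 2660 nM.
compound 2 `Cc1cccc(NC(=O)CCN2CCN(c3ccccn3)CC2)c1` — compound 2 is recorded as "not active" (no number reported) in this assay.
compound 3 `Cc1ccc(C2CCN(CC(=O)Nc3cccc(C)c3)CC2)cc1` — compound 3 is recorded as "not active" (no number reported) in this assay.

For the measured compounds named here, compound 1 stands as the only member of the set with a number in this assay; compounds 2 and 3 carry no number at all, so no step from either of them to compound 1 can be sized, and nothing beyond the fact that compound 1 alone produced a measurable response can be read from the pair.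

Compound 4 `O=C(CN1CCN(c2ccc(Cl)cn2)CC1)Nc1cccnc1` differs from compound 1 by chloro in place of hydrogen on an aromatic carbon, the pyridin-2-yl of the shared core becoming 5-chloropyridin-2-yl. Going by the values given here, no measured pair in the set shows this change, so its size has not been observed here. A single chloro in place of hydrogen on an aromatic carbon is, in the absence of any comparable step, expected to move the number only a little, most likely within the usual scatter, with a slight lean toward a lower value. The expected step is a 1.7-fold lower number from compound 1 to compound 4 (0.22 log units; within the scatter). Compound 4 is expected at about 1600 nM, between 450 nM and 6000 nM.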

Compound 4, half-maximal effective concentration: "not active" (no number reported)
The entry for compound 4 holds no number; no gap can be computed for the estimate.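

For the compounds shown here, compound 4 holds no number in this assay, so no step from compound 1 to compound 4 can be read. The compounds shown leave open how chloro in place of hydrogen shifts a measurable response in this series. No supporting data bear on this result.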